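Ring Chlorination After Chain Lengthening in HEp-2 Cytotoxicity

The source may hold more compounds than are shown below. What is called first, only, known or untested is meant among the compounds shown, and "the series" means these compounds.

Compound 1, `CC[C@@H](CCn1cncn1)c1ccc(Cl)cc1`: 55.1 ug/mL
Compound 2, `CCCC[C@@H](CCn1cncn1)c1ccc(Cl)cc1`: 17 ug/mL

For the measured compounds named here, in an ADME assay on HEp-2 cells (Homo sapiens) for cytotoxicity, read by MTT assay, with a stated time of 3 days (a lower number here means that less compound is tolerated, a higher number that more compound is tolerated), compound 2 stands lowest of the two measured numbers, and the step of a 3.2-fold lower number from compound 1 to compound 2 (0.51 log units; beyond the scatter) is the only measured step. Compound 3, `CCCC[C@@H](CCn1cncn1)c1ccc(Cl)cc1Cl`, differs from compound 2 by chloro in place of hydrogen on an aromatic carbon. Going by the values given here, no measured step places a group on an aromatic carbon, so that single step does not bear on this change, and the data give no guide of their own. Compound 3 is therefore expected to sit near compound 2, with a step of a 1.5-fold lower number from compound 2 to compound 3 (0.19 log units; within the scatter) not clearly beyond the scatter. Compound 3 is estimated at 11 ug/mL, within 5 ug/mL to 25 ug/mL.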

Compound 3, half-maximal cytotoxic concentration: 6.5 ug/mL
For compound 3 the middle estimate is 1.7-fold (0.23 log units) above the measured one; the range from low to high includes it.
By their numbers in this assay, from the lowest: compound 3; then compound 2; then compound 1.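

In this assay, the ring carbon ortho to a large group and meta to a chloro group proves sensitive to substitution: chloro in place of hydrogen there gives a 2.6-fold lower number from compound 2 to compound 3 (0.42 log units; beyond the scatter). For the compounds shown here, this is the first measured change on the ring rather than the chain, and it runs in the same direction as a 3.2-fold lower number from compound 1 to compound 2 (0.51 log units; beyond the scatter). Nothing measured here accounts for this result.

On these data alone, whether fluoro, methoxy or an amine at this carbon would shift the number in the same way remains open. So does the size of the chloro step on compound 1.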